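This account rests on a few compounds, and the source may have more. Where it says the series, first, only, none or still open, it means among the compounds named here.

Measured so far:
Compound 1, `NC(=O)c1c(NC(=O)c2ccccc2Cl)sc2c1CCN(Cc1ccccc1)C2`: 38400 nM
Compound 2, `NC(=O)c1c(NC(=O)c2ccccc2Cl)sc2c1CCN(C(=S)Nc1ccccc1I)C2`: 29000 nM

Among the compounds with values here, in a functional assay on HeLa cells (Homo sapiens) for antiproliferative activity, with a stated time of 24 h (a lower number here means a stronger inhibitor, a higher number a weaker inhibitor), compound 2 is one of only two measured compounds, the other being compound 1, and the step of a 1.3-fold lower number from compound 1 to compound 2 (0.12 log units; within the scatter) lies within the scatter, so the two stand level. Compound 3, `COc1ccccc1NC(=S)N1CCc2c(sc(NC(=O)c3ccccc3Cl)c2C(N)=O)C1`, keeps everything in compound 2 except one exchange: methoxy in place of iodo on an aromatic carbon. Within the data shown here, no measured step touches this group on the aromatic ring. Among the measured compounds shown here, the single step on record changes a different group, on an amine nitrogen in a ring, and is itself within the scatter, so it gives no direction for the present exchange. Both measured compounds are weak inhibitors and nothing shown suggests compound 3 would leave that range. Compound 3 is therefore expected to give about 30000 nM in this assay, with a range from 12000 nM to 80000 nM. The expected step of a 1.0-fold higher number from compound 2 to compound 3 (0.01 log units; within the scatter) is estimated to stay within the scatter.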

Compound 3, half-maximal inhibitory concentration: > 50000 nM
Compound 3: only a limit was reported; the forecaster's own chance of this, stated with the estimate: 10%; at least 1.6-fold (0.22 log units) between middle value and limit.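

In this assay, compound 3 gives only a limit and not a number: the limit of > 50000 nM in this assay, at which 1 of the 3 values shown sits. For methoxy in place of iodo on an aromatic carbon, ortho to a large group, the exchange reads an at least 1.7-fold higher number from compound 2 to compound 3 (0.23 log units; that floor lies within the scatter), and the change on the amine nitrogen in the ring reads an at least 1.3-fold higher number from compound 1 to compound 3 (0.11 log units; that floor lies within the scatter). Both floors stay within the scatter, so this position shows no gain from methoxy over iodo, and the size of any loss is not fixed.

The compounds shown leave open whether another group at this place, such as fluoro, methyl or hydroxyl, would give a stronger inhibitor than iodo or methoxy. Going by these compounds, how far compound 3 lies past its limit also stays unknown, so the true size of the iodo to methoxy step remains open.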